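The source may hold more compounds than are shown below. What is called first, only, known or untested is meant among the compounds shown, and "the series" means these compounds.

Compound 1 `COc1cc(C2CCN(C[C@@H](C)O)CC2)ccc1Nc1ncc2ccc(-c3ccccc3N(C)S(C)(=O)=O)n2n1` was tested in an in vitro ADME assay on microsomes from liver (Homo sapiens) for metabolic stability, using NADPH, with a stated time of 10 min, tested at 0.5 uM; a higher number here means that the compound lasts longer, a lower number that the compound disappears faster. For compound 1 the outcome is only a limit, < 0.0834 h, so it sits at the limit of < 0.0834 h in this assay, at which 1 of the 2 values shown sits. Compound 2 `COc1cc(C2CCNCC2)ccc1Nc1ncc2ccc(-c3ccccc3N(C)S(C)(=O)=O)n2n1`, which carries hydrogen in place of 2-hydroxypropyl on an amine nitrogen in a ring, gives 0.117 h in this assay. That change amounts to an at least 1.4-fold higher number from compound 1 to compound 2 (0.14 log units; that floor lies within the scatter). Compound 3 `COc1cc(C2CCN(C[C@@H](C)O)CC2)ccc1Nc1ncc2ccc(-c3ccccc3OC)n2n1` differs from compound 1 at another place: methoxy in place of methyl(methylsulfonyl)amino on an aromatic carbon. For the measured compounds named here, no measured step touches that part of the molecule, so no change beyond the scatter is expected in this assay. Compound 3 is estimated at 0.07 h, between 0.03 h and 0.2 h. As a step, the expectation reads a step that the limit leaves unreadable from compound 1 to compound 3.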

Compound 3, half-life: > 0.666 h
Compound 3 ended at the assay's limit (the forecaster's own chance of this, stated with the estimate: 55%); middle value at least 9.5-fold (0.97 log units) from the limit.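

The aromatic ring that carries this group turns out to be a sensitive place in this assay: replacing methyl(methylsulfonyl)amino with methoxy gives an at least 7.9-fold higher number from compound 1 to compound 3 (0.90 log units; beyond the scatter). Compound 1 stands at a limit: the limit of < 0.0834 h in this assay, at which 1 of the 3 values shown sits. Compound 3 also stands at a limit: the limit of > 0.666 h in this assay, at which 1 of the 3 values shown sits.

As far as these compounds go, whether the rise comes from removing methyl(methylsulfonyl)amino or from adding methoxy stays open. Compounds with a plain hydrogen, a methyl or an ethoxy group at this place could help separate those two readings.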